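Replacing pyridin-2-yl with 3-methoxyphenyl on compound 1

The source may hold more compounds than are shown below. What is called first, only, known or untested is meant among the compounds shown, and "the series" means these compounds.

In a functional assay on the whole organism with Rattus norvegicus as the target (on this read-out higher numbers stand for an effect only at larger amounts of compound and lower numbers for an effect already at smaller amounts), compound 1 `CCN(CCNC(=O)c1cc(Cl)c(N)cc1OC)Cc1ccccn1` gives 30 mg/kg, the higher of the two numbers available, while compound 2 `COc1cc(N)c(Cl)cc1C(=O)NCCN(C)CC1CCCCC1` gives 3 mg/kg, a gap beyond the usual scatter. These two compounds differ in more than one place, so no single structural change can be read from them. Compound 3 `CCN(CCNC(=O)c1cc(Cl)c(N)cc1OC)Cc1cccc(OC)c1` has not yet been measured. It carries 3-methoxyphenyl in place of pyridin-2-yl on a saturated chain carbon bound to an amine nitrogen. Among the measured compounds shown here, no measured single-place step guides this change. A moderate move toward lower numbers is expected, resting only on compound 2 at 3 mg/kg, which shows that lower values occur among these compounds. The expected step is a 2.5-fold lower number from compound 1 to compound 3 (0.40 log units; beyond the scatter). In this assay the estimate for compound 3 is 12 mg/kg, within a range of 3 mg/kg to 40 mg/kg.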

Compound 3, dose for half-maximal effect: 1 mg/kg
Compound 3: the middle estimate sits 12-fold (1.08 log units) above what was measured; the measured number lies below the stated range.
By their numbers in this assay, from the lowest: compound 3; then compound 2; then compound 1.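

Replacing pyridin-2-yl with 3-methoxyphenyl on a saturated chain carbon bound to an amine nitrogen gives a 30-fold lower number from compound 1 to compound 3 (1.48 log units; beyond the scatter) in this assay, the first single-place comparison among these compounds, and it shows that the read-out responds strongly to the group at this position. The two groups have the same counts of hydrogen-bond donors and acceptors and neither carries a net charge, so the large step arises even though those counts stay the same. Nothing available explains why this exchange has so large an effect.

As far as these compounds go, the change removes the ring nitrogen and adds the methoxy group in a single step, so the share of each remains open. A plain phenyl group at this position would separate the two contributions, and a 3-ethoxyphenyl group would show whether a longer chain on the oxygen is compatible with the lower number.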